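A few compounds are considered here, and "the series" means these few. Any claim that something is new, unique, unknown or untested is made for them only; others in the source may bear on it.

Of the compounds shown here, two of one shared core have been measured so far. Compound 1, `CC1(C)N=C(N)N=C(N)N1c1ccccc1N`, carries an amino group on the aromatic ring and in an assay for inhibition of Dihydrofolate reductase (Bos taurus), at pH 7.20 (on this read-out lower numbers stand for lower potency and higher numbers for higher potency (the scale is a negative logarithm)), compound 1 gives 4.58. Compound 2, `CC1(C)N=C(N)N=C(N)N1c1ccccc1F`, carries fluoro at the same position instead, and in this assay compound 2 gives 5.41. For the measured compounds named here, the one step between them, a number 0.83 log units higher from compound 1 to compound 2 (beyond the scatter), is a modest rise that lies beyond the usual scatter. Compound 2 therefore stands as the higher of the two numbers, with compound 1 as its nearest neighbour a modest distance below.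

Compound 3, `CC1(C)N=C(N)N=C(N)N1c1ccccc1I`, has not yet been measured in this assay. It differs from compound 2 in one place: iodo in place of fluoro on an aromatic carbon. Going by the values given here, no measured step in this set exchanges one halogen for another; the only step available, from amino to fluoro, went up, and it does not bear directly on a change from fluoro to iodo. The direction for compound 3 is thus not settled by the data. Compound 3 is estimated at 5.8, within a range from 5 to 6.6, which as a step from compound 2 would be a number 0.39 log units higher from compound 2 to compound 3 (beyond the scatter), a small expected rise that may well fall within the scatter.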

Compound 3, logarithm of the reciprocal of the active concentration, log(1/C): 3.75
For compound 3 the middle estimate is 2.05 log units above the measured one, and the stated range ends above it.
By their numbers in this assay, from the lowest: compound 3; then compound 1; then compound 2.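

The result shows that this position, on an aromatic carbon ortho to a large group, does not treat one halogen like another: in this assay, iodo in place of fluoro gives a number 1.66 log units lower from compound 2 to compound 3 (beyond the scatter), a large step in the downward direction, whereas the earlier compounds had shown only a rise on going from amino to fluoro. Amino also no longer marks the low end of the series, since iodo in place of amino gives a number 0.83 log units lower from compound 1 to compound 3 (beyond the scatter), so that among these three groups fluoro stands highest, amino in the middle and iodo lowest, each separated from the others by more than the scatter. Nothing available here accounts for the drop from fluoro to iodo, and the data offer no measured property of these groups to set beside it.

The compounds shown leave open whether the number falls gradually or abruptly between fluoro and iodo, a question that chloro and bromo at this same position would address. They also leave open how a methyl group or a plain hydrogen there would compare, and whether the order of these three groups would hold at any other carbon of the aromatic ring.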